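Swapping the Nitrophenyl Arm of Compound 3 for Methoxyphenyl

The source may hold more compounds than are shown below. What is called first, only, known or untested is meant among the compounds shown, and "the series" means these compounds.

In a functional assay on PC-3 cells (Homo sapiens) for cytotoxicity, read by sulforhodamine B assay (a higher number here means a weaker inhibitor of growth, a lower number a stronger inhibitor of growth), the three measured compounds stand as follows:
compound 1 `COc1cccc(OC)c1OCCNCCOc1ccccc1OCc1cccc(Cl)c1` gives 5900 nM
compound 2 `COc1cccc(OC)c1OCCNCCOc1ccccc1OCc1ccc(C)cc1` gives 7800 nM
compound 3 `COc1cccc(OC)c1OCCNCCOc1ccccc1OCc1ccccc1[N+](=O)[O-]` gives 13200 nM

Compound 3 has the highest number of the three in this assay, a modest step beyond the scatter from compound 1 (a 2.2-fold higher number from compound 1 to compound 3 (0.35 log units; beyond the scatter)), and within the scatter of compound 2 (a 1.7-fold higher number from compound 2 to compound 3 (0.23 log units; within the scatter)). Compound 4 `COc1cccc(COc2ccccc2OCCNCCOc2c(OC)cccc2OC)c1` differs from compound 3 in one place: 3-methoxyphenyl in place of 2-nitrophenyl on a saturated chain carbon bound to an oxygen on an aromatic ring. The two steps that bear on this change are those onto the 2-nitrophenyl group, and both moved the number upward, one beyond the scatter. Removing that group in favour of 3-methoxyphenyl is therefore expected to bring the number back toward compounds 1 and 2, a small downward step in this assay. Compound 4 is expected to give 7500 nM, between 3500 nM and 16000 nM, which means a 1.8-fold lower number from compound 3 to compound 4 (0.25 log units; within the scatter).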

Compound 4, concentration for 50% growth inhibition: 2500 nM
The estimate for compound 4 lay 3.0-fold (0.48 log units) above the measured number; measured number outside the range, below it.
By their numbers in this assay, from the lowest: compound 4; then compounds 1, 2 and 3 (each within the scatter of the next, the first and the last beyond it).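

In this assay the 3-methoxyphenyl arm gives the lowest number of the four, and each step onto it lies beyond the scatter: a 5.3-fold lower number from compound 3 to compound 4 (0.72 log units; beyond the scatter) and a 3.1-fold lower number from compound 2 to compound 4 (0.49 log units; beyond the scatter) and a 2.4-fold lower number from compound 1 to compound 4 (0.37 log units; beyond the scatter). Among the compounds shown here, until now the only step beyond the scatter at this position was a rise, onto 2-nitrophenyl. Compound 4 shows that a change here can also lower the number, even when methoxy simply replaces chloro on an aromatic carbon.

Nothing available gives a reason for this fall. From the compounds shown here alone, whether an ethoxy or a hydroxy group in place of methoxy would keep the number this low remains open.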